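Aryl ketone variation on the shared core: indolyl replacing thienyl

A few compounds are considered here, and "the series" means these few. Any claim that something is new, unique, unknown or untested is made for them only; others in the source may bear on it.

Measured so far:
- compound 1, `COc1ccc(-c2cc3ccccc3nc2/C=C/C(=O)c2ccc([N+](=O)[O-])cc2)cc1`: 590 nM
- compound 2, `COc1ccc(-c2cc3ccccc3nc2/C=C/C(=O)c2cccs2)cc1`: 800 nM

Both compounds share the same core and differ only in the group on the carbonyl carbon. In a functional assay on SK-BR-3 cells (Homo sapiens) for antiproliferative activity, read by XTT assay, with a stated time of 72 h (a higher number here means a weaker inhibitor, a lower number a stronger inhibitor), compound 1 gives 590 nM, and in this assay compound 2 gives 800 nM. Among the measured compounds shown here, the only step in hand, a 1.4-fold higher number from compound 1 to compound 2 (0.13 log units; within the scatter), does not exceed the scatter, so compound 2 stands at the higher of the two numbers without being separable from compound 1. Compound 3, `COc1ccc(-c2cc3ccccc3nc2/C=C/C(=O)c2c[nH]c3ccccc23)cc1`, carries the change (1H-indol-3-yl in place of thiophen-2-yl on a carbonyl carbon). For the measured compounds named here, the single measured step concerns the same position and shows that swapping one aryl group for another there left the number essentially unchanged. Going by the values given here, that step is the only evidence bearing on the new change; nothing speaks to a bicyclic group with a hydrogen-bond donor at this position, so the expectation rests on the observed insensitivity alone. The step is therefore expected to be a 1.2-fold lower number from compound 2 to compound 3 (0.09 log units; within the scatter) in this assay, with no clear direction. Compound 3 is estimated at 650 nM, with a range from 220 nM to 2000 nM.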

Compound 3, half-maximal inhibitory concentration: 3450 nM
For compound 3 the middle estimate is 5.3-fold (0.72 log units) below the measured one; the measured number lies above the stated range.
By their numbers in this assay, from the lowest: compounds 1 and 2 (each within the scatter of the next); then compound 3.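

In this assay the carbonyl carbon position proves sensitive to the group it carries: 1H-indol-3-yl gives a 4.3-fold higher number from compound 2 to compound 3 (0.63 log units; beyond the scatter) and a 5.8-fold higher number from compound 1 to compound 3 (0.77 log units; beyond the scatter). The insensitivity suggested by the earlier swap between 4-nitrophenyl and thiophen-2-yl therefore does not extend to every aromatic group at this position, and compound 3 stands apart from both compound 1 and compound 2, each step lying beyond the scatter. The change adds heavy atoms, a six-membered aromatic ring and a hydrogen-bond donor in one step, and no supporting measurement is available to explain the higher number.

The compounds shown leave open whether the second ring or the indole hydrogen accounts for the step, since these two features enter together in compound 3. A benzothiophen-3-yl or 1-methyl-1H-indol-3-yl group would keep both rings without that hydrogen, a pyrrol-3-yl group would keep the hydrogen on a single ring, and comparing these on the carbonyl carbon would separate the two features.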